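The compounds below may be only part of what the source reports. "The series", "measured", "known", "first", "only" and "open" are said of these compounds alone.

Compound 1 `COc1cc(/C=C2\CN(C)C/C(=C\c3ccccc3F)C2=O)cc(OC)c1`: 11900 nM
Compound 2 `CN1C/C(=C\c2cccc([N+](=O)[O-])c2)C(=O)/C(=C/c2ccccc2F)C1`: 13500 nM
Compound 3 `COc1cc(/C=C2\CN(C)C/C(=C\c3ccc(F)cc3)C2=O)cc(OC)c1`: 21900 nM

Three compounds were measured in an ADME assay on L02 cells (Homo sapiens) for cytotoxicity, read by MTT assay, with a stated time of 24 h; on this read-out higher numbers stand for weaker inhibition and lower numbers for stronger inhibition. Compound 1 `COc1cc(/C=C2\CN(C)C/C(=C\c3ccccc3F)C2=O)cc(OC)c1` gives 11900 nM in this assay. Among the compounds with values here, compound 3 `COc1cc(/C=C2\CN(C)C/C(=C\c3ccc(F)cc3)C2=O)cc(OC)c1` carries the change 4-fluorophenyl in place of 2-fluorophenyl on a double-bonded chain carbon bound to a double-bonded ring carbon on the core of compound 1, and in this assay compound 3 gives 21900 nM; the step of a 1.8-fold higher number from compound 1 to compound 3 (0.26 log units; within the scatter) is the only measured instance of this change. Compound 2 `CN1C/C(=C\c2cccc([N+](=O)[O-])c2)C(=O)/C(=C/c2ccccc2F)C1` gives 13500 nM in this assay; it stands on a different core from compound 1, and the difference between the two cores is not broken down here, so only the two values themselves can be compared, and they lie within the scatter of each other.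

Compound 4 `CN1C/C(=C\c2ccc(F)cc2)C(=O)/C(=C/c2cccc([N+](=O)[O-])c2)C1` has not yet been measured. Within the data shown here, it relates to compound 2 through the change (4-fluorophenyl in place of 2-fluorophenyl on a double-bonded chain carbon bound to a double-bonded ring carbon), which is the same change as the one from compound 1 to compound 3, made at the same place. Because the measured step of a 1.8-fold higher number from compound 1 to compound 3 (0.26 log units; within the scatter) is within the scatter, the corresponding step on the core of compound 2 is expected to be of similar size, and the expected step is a 1.4-fold higher number from compound 2 to compound 4 (0.15 log units; within the scatter). This expectation rests on a single measured pair and on the value of compound 2 13500 nM, and a second core may respond differently. On that basis compound 4 is estimated to give 19000 nM in this assay, with an expected range from 9500 nM to 38000 nM.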

Compound 4, half-maximal inhibitory concentration: 17600 nM
Compound 4: the middle estimate sits 1.1-fold (0.03 log units) above what was measured; measured number inside the range.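

In this assay, placing 4-fluorophenyl in place of 2-fluorophenyl on a double-bonded chain carbon bound to a double-bonded ring carbon gives a 1.3-fold higher number from compound 2 to compound 4 (0.12 log units; within the scatter) on the core of compound 2. Set beside the earlier instance of the same change, the two steps do not differ beyond what repeated measurements would be expected to show: the same change on two cores in this assay, a 1.8-fold higher number (0.26 log units; within the scatter) from compound 1 to compound 3 and a 1.3-fold higher number (0.12 log units; within the scatter) from compound 2 to compound 4, 1.4-fold (0.15 log units) apart, within the scatter of two such steps. This shows that the change carried from one core to the other without any detectable difference in its size, but both steps lie within the scatter, so the two pairs neither establish that the change has a real effect of its own on this read-out nor show that it would transfer in the same way to a further core.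

The compounds shown leave open whether a larger step would appear if something other than fluorine sat on this phenyl ring, such as a chlorine atom, an amine or a carboxylic acid. Within the data shown here, they also leave open whether the agreement holds on cores carrying other aryl groups on the second double-bonded chain carbon, since only two such cores appear here, one with a dimethoxyphenyl group and one with a nitrophenyl group.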